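The compounds below may be only part of what the source reports. "The series", "measured", "known", "first", "only" and "open" are said of these compounds alone.

Compound 1, `CCC(COc1ccccc1Cl)OC(=O)NCc1ccccc1`, is measured in an assay for inhibition of zeta-carotene desaturase, chloroplastic/chromoplastic (Capsicum annuum), using a Dixon plot, with a stated time of 8 h (a lower number here means a stronger inhibitor, a higher number a weaker inhibitor), where compound 1 gives > 100000 nM, a limit of the assay rather than a number. In this assay compound 2, `CCC(COc1cccc(F)c1)OC(=O)NCc1ccccc1`, gives > 100000 nM, also a limit. In this assay compound 3, `CCC(COc1cccc(C#N)c1)OC(=O)NCc1ccccc1`, gives > 100000 nM, again a limit. Compound 1 thus stands with the other two at the limit of > 100000 nM in this assay, at which 3 of the 3 values shown sit, and the steps a step that the two limits leave unreadable from compound 1 to compound 2, a step that the two limits leave unreadable from compound 1 to compound 3 and a step that the two limits leave unreadable from compound 2 to compound 3 cannot be read. Compound 4, `CCC(COc1c(Cl)cccc1Cl)OC(=O)NCc1ccccc1`, differs from compound 1 by chloro in place of hydrogen on an aromatic carbon. Among the compounds with values here, no measured step bears on this change; every value shown is a limit. Compound 4 is therefore expected to stay near that limit, estimated at 150000 nM with a range of 30000 nM to 1000000 nM. The expected step is a step that the limit leaves unreadable from compound 1 to compound 4.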

Compound 4, half-maximal inhibitory concentration: > 100000 nM
Compound 4: a limit, no number (the forecaster's own chance of this, stated with the estimate: 85%); the middle value is on the limit's open side.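

In this assay compound 4 gives > 100000 nM, a limit, so its steps from compound 1, compound 2 and compound 3 cannot be read: the limit of > 100000 nM in this assay, at which 4 of the 4 values shown sit. The compounds shown leave open whether any of these aromatic changes alters inhibition at all.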